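Moving the carboxylic acid around the terminal aryl ring

The source may hold more compounds than are shown below. What is called first, only, known or untested is meant among the compounds shown, and "the series" means these compounds.

Measured so far:
compound 1, `COc1ccc(C(=O)O)cc1OCCCCOc1ccc(C(=O)CC(C)C)c(O)c1C`, 737 nM
compound 2, `Cc1ccc(C(=O)O)cc1OCCCCOc1ccc(C(=O)CC2CCCC2)c(O)c1C`, limit > 10000 nM
compound 3, `Cc1cc(C(=O)O)ccc1OCCCCOc1ccc(C(=O)CC(C)C)c(O)c1C`, 1850 nM

In an assay on HEK293 cells for positive allosteric modulation of metabotropic glutamate receptor 3 (Rattus norvegicus), read by thallium flux, with a stated time of 2.5 min (a lower number here means that less compound is needed, a higher number that more compound is needed for the effect), compound 3 gives 1850 nM, the highest of the two numbers seen. Compound 1 gives 737 nM, a step down from compound 3 beyond the usual scatter. For compound 2 the assay reports only a limit, > 10000 nM, not a number.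

Compound 4, `Cc1ccc(C(=O)O)cc1OCCCCOc1ccc(C(=O)CC(C)C)c(O)c1C`, has not been measured. It differs from compound 3 by 5-carboxy-2-methylphenyl in place of 4-carboxy-2-methylphenyl on an oxygen on a saturated carbon. Two neighbours, one that reads better and one at the limit, leave the direction uncertain. A modest improvement is expected, a 1.9-fold lower number from compound 3 to compound 4 (0.27 log units; within the scatter). For compound 4 the estimate in this assay is 1000 nM, within 300 nM to 3500 nM.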

Compound 4, half-maximal effective concentration: > 10000 nM
Compound 4 was reported as a limit; the forecaster's own chance of this, stated with the estimate: 15%; at least 10-fold (1.00 log units) between middle value and limit.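

In this assay, 5-carboxy-2-methylphenyl in place of 4-carboxy-2-methylphenyl gives an at least 5.4-fold higher number from compound 3 to compound 4 (0.73 log units; beyond the scatter), so with the same atoms joined differently, where the carboxylic acid sits on this ring clearly matters. With this acid placement, methyl in place of methoxy on an aromatic carbon gives an at least 13-fold higher number from compound 1 to compound 4 (1.13 log units; beyond the scatter), so one small ring group also counts. Compound 2 and compound 4 both end at a limit, so the step between them cannot be read: the limit of > 10000 nM in this assay, at which 2 of the 4 values shown sit.

On these data alone, how far past the limit compound 4 lies remains open. So does whether an amide in place of the carboxylic acid would keep the effect.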